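The source may hold more compounds than are shown below. What is called first, only, known or untested is meant among the compounds shown, and "the series" means these compounds.

Measured compounds:
compound 1 `N#CC1=C(N)Oc2c(c3nc4ccccc4nc3c3ccccc23)C12C(=O)N(Cc1cnnn1-c1ccc(Cl)cc1)c1ccccc12`; in a functional assay on HCT-116 cells (Homo sapiens) for antiproliferative activity, read by MTT assay, with a stated time of 48 h (on this read-out lower numbers stand for stronger inhibition and higher numbers for weaker inhibition), compound 1 gives > 50000 nM, a limit of the assay.
compound 2 `N#CC1=C(N)Oc2c(c3nc4ccccc4nc3c3ccccc23)C12C(=O)N(Cc1cnnn1-c1ccc(Br)cc1)c1ccccc12`; in this assay compound 2 gives > 50000 nM, again a limit.
compound 3 `N#CC1=C(N)Oc2c(N)cc3nc4ccccc4nc3c2C12C(=O)N(Cc1cnnn1-c1ccc(F)cc1)c1ccccc12`; in this assay compound 3 gives > 50000 nM, also a limit.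

Compound 3 thus stands at the limit, as does every value shown (the limit of > 50000 nM in this assay, at which 3 of the 3 values shown sit). Going by the values given here, the only measured step, a step that the two limits leave unreadable from compound 1 to compound 2, lies between two limits and its size cannot be read. Compound 4 `N#CC1=C(N)Oc2c(N)cc3nc4ccccc4nc3c2C12C(=O)N(Cc1cnnn1-c1cccc(C(F)(F)F)c1)c1ccccc12` differs from compound 3 by 3-(trifluoromethyl)phenyl in place of 4-fluorophenyl on an aromatic nitrogen. Among the compounds with values here, no measured step touches this change, and the three limits give no size for it in this assay; no step beyond the scatter can be read in either direction. Compound 4 is therefore expected to remain at the limit, estimated at 60000 nM (range 20000 nM to 200000 nM). The expected step is a step that the limit leaves unreadable from compound 3 to compound 4.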

Compound 4, half-maximal inhibitory concentration: 18900 nM
Compound 4: middle estimate off by 3.2-fold (0.50 log units), on the high side; the measured number lies below the stated range.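

Putting 3-(trifluoromethyl)phenyl in place of 4-fluorophenyl on the aromatic nitrogen gives an at least 2.6-fold lower number from compound 3 to compound 4 (0.42 log units; beyond the scatter) in this assay, so a change at this position can bring the read-out off the limit. Going by these compounds alone, this is the only readable step, as the steps between limits cannot be read. The other values shown remain at the limit: the limit of > 50000 nM in this assay, at which 3 of the 4 values shown sit.

Going by these compounds, because the step starts from a limit, its full size stays open. Also open, on these data alone, is whether 4-(trifluoromethyl)phenyl, or a carboxylic acid or an amine on this phenyl ring, would move the number further.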